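From 4-Ethylphenyl to 4-Methylphenyl: Expecting Compound 4

The source may report more compounds than this note shows. Statements on the series, on what has been measured and on what is new or still open speak of the compounds shown alone.

Compound 3 `CCc1ccc(N2C(=O)NC3(CSC4=C3C(=O)c3ncccc3C4=O)C2=O)cc1` is measured in a functional assay on HeLa cells (Homo sapiens) for antiproliferative activity, read by MTT assay, with a stated time of 96 h (on this read-out higher numbers stand for weaker inhibition and lower numbers for stronger inhibition), at 5 nM. On that read-out compound 3 stands second highest of three numbers, yet both other compounds lie within the scatter of it: compound 2 `O=C1C2=C(C(=O)c3ncccc31)C1(CS2)NC(=O)N(c2ccccc2)C1=O` gives 3 nM, and compound 1 `CN(C)c1ccc(N2C(=O)NC3(CSC4=C3C(=O)c3ncccc3C4=O)C2=O)cc1` gives 10 nM. Compound 4 `Cc1ccc(N2C(=O)NC3(CSC4=C3C(=O)c3ncccc3C4=O)C2=O)cc1` differs from compound 3 by hydrogen in place of methyl on a saturated chain carbon bound to an aromatic carbon. The step bearing most directly on this change is a 1.7-fold higher number from compound 2 to compound 3 (0.22 log units; within the scatter), which places ethyl and hydrogen within the scatter of each other, and methyl lies between those two groups; a 2.0-fold lower number from compound 1 to compound 3 (0.30 log units; within the scatter) likewise shows little movement from a different group at the same place. Compound 4 is therefore expected to show no step beyond the scatter, no change at the digits printed from compound 3 to compound 4 (within the scatter). The estimated value for compound 4 is 5 nM, with a range from 2.5 nM to 10 nM.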

Compound 4, half-maximal inhibitory concentration: 2 nM
For compound 4 the middle estimate is 2.5-fold (0.40 log units) above the measured one; measured number outside the range, below it.
By their numbers in this assay, from the lowest: compounds 4, 2, 3 and 1 (each within the scatter of the next, the first and the last beyond it).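

In this assay, for the compounds shown here, the change from 4-ethylphenyl to 4-methylphenyl gives a 2.5-fold lower number from compound 3 to compound 4 (0.40 log units; beyond the scatter) and shows that removing one carbon from this chain can produce a step beyond the scatter, which no earlier step involving ethyl did. Yet a 1.5-fold lower number from compound 2 to compound 4 (0.18 log units; within the scatter) leaves methyl and hydrogen unresolved on the aromatic carbon, while a 5.0-fold lower number from compound 1 to compound 4 (0.70 log units; beyond the scatter) is the first step from dimethylamino to a carbon substituent that clears the scatter. No measurement here explains the difference between ethyl and methyl. The compounds shown leave open whether a propyl chain, a methoxy group or a chlorine atom at this aromatic carbon would track methyl or ethyl.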